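Chloro in Place of Fluoro on Compound 2

The source may report more compounds than this note shows. Statements on the series, on what has been measured and on what is new or still open speak of the compounds shown alone.

Measured compounds:
compound 1 `O=C(/C=C\Nc1ccc(F)cc1)c1cn(-c2ccccc2)nc1-c1ccc(F)cc1` — > 50000 nM
compound 2 `COc1cc(-c2nn(-c3ccccc3)cc2C(=O)/C=C\Nc2ccc(F)cc2)cc(OC)c1OC` — 25700 nM

In an ADME assay on HaCaT cells (Homo sapiens) for antiproliferative activity, read by MTT assay, with a stated time of 48 h (on this read-out higher numbers stand for weaker inhibition and lower numbers for stronger inhibition), compound 1 gives > 50000 nM, which is a limit of the assay and not a number. Compound 2 gives 25700 nM in this assay; it is the only number shown. The other of the two values, that of compound 1, sits at a limit (the limit of > 50000 nM in this assay, at which 1 of the 2 values shown sits). Within the data shown here, with no second numbered value, no step between measured compounds can be drawn, and the values of compound 1 and compound 2 show only that compound 2 sits within the measured range while compound 1 does not.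

Compound 3 `COc1cc(-c2nn(-c3ccccc3)cc2C(=O)/C=C\Nc2ccc(Cl)cc2)cc(OC)c1OC` differs from compound 2 in one place: chloro in place of fluoro on an aromatic carbon. Among the measured compounds shown here, for a change of this kind, with no measured step to lean on, the expected size of the step in this assay is none beyond the usual scatter, in no settled direction. Compound 3 is therefore estimated to give 22000 nM, between 8000 nM and 50000 nM, which means an expected step of a 1.2-fold lower number from compound 2 to compound 3 (0.07 log units; within the scatter).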

Compound 3, half-maximal inhibitory concentration: 30200 nM
Estimate against measurement, compound 3: 1.4-fold (0.14 log units) below; the measured number falls inside the stated range.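

In this assay, among these compounds, the exchange on this aromatic carbon, para to a large group, gives a 1.2-fold higher number from compound 2 to compound 3 (0.07 log units; within the scatter), the first step that can be read. Within this small set, 4-fluorophenyl and 4-chlorophenyl on the amino side of compound 2 and compound 3 therefore cannot be told apart, and this one change at this position gives no measurable gain or loss. Nothing on hand about fluoro or chloro bears on why the two compounds cannot be told apart.

Whether a trifluoromethyl, a nitrile, an amine or a carboxylic acid at the same position would give a step beyond the scatter remains open, as the only exchange shown here is between chloro and fluoro. Going by these compounds, compound 1 gives > 50000 nM, which is a limit of the assay and not a number, and whether the same exchange would behave alike on the core of compound 1 also remains open.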